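Piperidin-1-yl in place of a longer piperazine chain

The source may hold more compounds than are shown below. What is called first, only, known or untested is meant among the compounds shown, and "the series" means these compounds.

Within the data shown here, in a functional assay on HCT-116 cells (Homo sapiens) for cytotoxicity, read by MTT assay, with a stated time of 72 h (a higher number here means a weaker inhibitor, a lower number a stronger inhibitor), compound 2 `O=C1c2c[n+]([O-])c3ccccc3c2C(=O)c2c1c1ccccc1n2CCCCN1CCNCC1` gives 700 nM, the highest of the three numbers so far. Compound 1 `O=C1c2c[n+]([O-])c3ccccc3c2C(=O)c2c1c1ccccc1n2CCN1CCCC1` gives 270 nM, and compound 3 `CC1(C)OC[C@H](Cn2cc(Cn3c4c(c5ccccc53)C(=O)c3c[n+]([O-])c5ccccc5c3C4=O)nn2)O1` gives 130 nM. Compound 4 `O=C1c2c[n+]([O-])c3ccccc3c2C(=O)c2c1c1ccccc1n2CCN1CCCCC1` is not yet measured. It differs from compound 2 by one change on a saturated chain carbon: piperidin-1-yl in place of 2-(piperazin-1-yl)ethyl on a saturated chain carbon, two bonds along the chain from an aromatic nitrogen. Among the measured compounds shown here, one measured step bears on this, a 2.6-fold higher number from compound 1 to compound 2 (0.41 log units; beyond the scatter), a modest change in which 2-(piperazin-1-yl)ethyl replaced pyrrolidin-1-yl at that same place. The new change removes 2-(piperazin-1-yl)ethyl, so a modest move toward a lower number is expected, though this rests on a single step. The expected step is a 2.5-fold lower number from compound 2 to compound 4 (0.40 log units; beyond the scatter). For compound 4, the estimated value is 280 nM, within an expected range of 130 nM to 600 nM.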

Compound 4, half-maximal inhibitory concentration: 780 nM
For compound 4 the middle estimate is 2.8-fold (0.44 log units) below the measured one; measured number outside the range, above it.
By their numbers in this assay, from the lowest: compound 3; then compound 1; then compounds 2 and 4 (each within the scatter of the next).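

In this assay, a 1.1-fold higher number from compound 2 to compound 4 (0.05 log units; within the scatter) shows that piperidin-1-yl and 2-(piperazin-1-yl)ethyl cannot be told apart at this place on the chain, so losing the piperazine does not by itself bring the number down. Piperidin-1-yl in place of pyrrolidin-1-yl gives a 2.9-fold higher number from compound 1 to compound 4 (0.46 log units; beyond the scatter), so a change of the ring alone, on the same chain, is enough to separate two compounds. Nothing measured here explains either result. Still open, as far as these compounds go, is whether morpholin-4-yl or an open-chain amine such as diethylamino at this place would give a number closer to compound 1 or to compounds 2 and 4.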